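The compounds below may be only part of what the source reports. "The series", "measured", "known", "first", "only" and "open" are said of these compounds alone.

Measured compounds:
compound 1, `CC1=C(C(=O)OCc2ccccc2)C(c2ccoc2)NC(=O)N1`, gives 1%
compound 2, `CC1=C(C(=O)C2CC2)C(c2ccoc2)NC(=O)N1`, gives 16%
compound 3, `CCN(CC)C(=O)C1=C(C)NC(=O)NC1c1ccoc1`, gives 37%

These three were tested in an assay on membranes from HeLa cells for displacement of a labelled ligand from adenosine receptor A3 (Homo sapiens), read by scintillation counting, with a stated time of 180 min, tested at 1 uM; a higher number here means more inhibition at the concentration tested (going by the name of the read-out), a lower number less inhibition. Compound 3 stands highest of the three numbers; its nearest neighbour is compound 2, and its furthest is compound 1, whose value sits far below it. Compound 4, `CCC(CC)OC(=O)C1=C(C)NC(=O)NC1c1ccoc1`, has not been measured. It differs from compound 3 in one place: (pentan-3-yl)oxy in place of diethylamino on a carbonyl carbon. For the measured compounds named here, only one measured step touches this carbonyl carbon: a number 21 percentage points higher from compound 2 to compound 3 (beyond the scatter), where diethylamino in place of cyclopropyl raised the number. Going by the values given here, the remaining pair, compound 1 and compound 3, shows that a carbonyl carbon bearing diethylamino gives a far higher number than one bearing benzyloxy, but no step for that pair is given, so it is only read as two values. Since compound 4 carries an oxygen-linked group at the carbonyl carbon, as compound 1 does, rather than the diethylamino group of compound 3, the account expects a drop, and the step of a number 25 percentage points lower from compound 3 to compound 4 (beyond the scatter) is the estimated size of it in this assay. For compound 4 the estimated value is 12%, with a range from 0% to 30%.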

Compound 4, a percentage reported as inhibition, at one concentration (the size of the read-out at that concentration, not a potency): 5%
For compound 4 the middle estimate is 7 percentage points above the measured one, within the range that was stated.
By their numbers in this assay, from the lowest: compounds 1 and 4 (each within the scatter of the next); then compound 2; then compound 3.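

In this assay, for the compounds shown here, the change at this carbonyl carbon from diethylamino to (pentan-3-yl)oxy gives a number 32 percentage points lower from compound 3 to compound 4 (beyond the scatter) and is the first direct comparison of a nitrogen-linked group with an oxygen-linked one here. The identity of the group on the oxygen matters far less in this small set, since pentan-3-yl in place of benzyl gives a number 4 percentage points higher from compound 1 to compound 4 (within the scatter) and so leaves the two oxygen-linked compounds level, whether the group on that oxygen is branched or carries a ring. The cyclopropyl group, attached through carbon, also keeps a small edge over the oxygen-linked group of compound 4, as a number 11 percentage points lower from compound 2 to compound 4 (beyond the scatter) shows, so all three kinds of attachment now have a place in this assay, with diethylamino highest.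

Nothing available explains why the number falls with this change. On these data alone, it remains open whether the higher number belongs to diethylamino alone or would also appear with dimethylamino, a ring amine such as piperidine, or a secondary amide carrying a single ethyl group at this carbonyl carbon, and how a carboxylic acid there would compare.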